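A few compounds are considered here, and "the series" means these few. Any claim that something is new, unique, unknown or untested is made for them only; others in the source may bear on it.

Measured compounds:
Compound 1, `COc1cccc(-c2nc3cc(F)ccc3[nH]2)c1Cl`, gives 2620 nM.
Compound 2, `COc1cc(-c2nc3cc(F)ccc3[nH]2)ccc1OC(C)=O`, gives 1680 nM.
Compound 3, `COc1cc(-c2nc3cc(Cl)ccc3[nH]2)ccc1OC(C)=O`, gives 1680 nM.

All three numbers come from an assay for inhibition of Alpha amylase (Homo sapiens), with a stated time of 10 min; on this read-out higher numbers stand for weaker inhibition and lower numbers for stronger inhibition. Compound 1 and compound 2 share the same two-ring heterocycle but carry different substituted phenyl groups; the difference between the two cores is not broken down here, so the values of compound 1 and compound 2 can only be set side by side, and they lie within the usual scatter of each other.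

Within the series of compound 2 the one change that is measured is chloro in place of fluoro on an aromatic carbon. That step is no change at the digits printed from compound 2 to compound 3 (within the scatter).

Compound 4, `COc1cccc(-c2nc3cc(Cl)ccc3[nH]2)c1Cl`, has not yet been measured in this assay. It is made from compound 1 by the same change, (chloro in place of fluoro on an aromatic carbon), at a place described in the same words as the place in compound 3. Because no change at the digits printed from compound 2 to compound 3 (within the scatter) shows no movement at the printed digits, the expectation for compound 4 is that it stays close to compound 1, allowing for scatter on either side. Compound 4 is therefore estimated at 2500 nM in this assay, with an expected range from 1200 nM to 5200 nM. For compound 4 the expected step is a 1.0-fold lower number from compound 1 to compound 4 (0.02 log units; within the scatter), set beside the measured step for the same change. This expectation rests on a single measured pair, so it carries the uncertainty of one example.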

Compound 4, half-maximal inhibitory concentration: 2780 nM
Compound 4: middle estimate off by 1.1-fold (0.05 log units), on the low side; the measured number falls inside the stated range.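

In this assay, the newly measured swap of chloro in place of fluoro gives a 1.1-fold higher number from compound 1 to compound 4 (0.03 log units; within the scatter). Set beside the earlier step on the other core, the result is the same, so in this series the swap carries from one core to the other without a visible effect on the number: the same change on two cores in this assay, no change at the digits printed (within the scatter) from compound 2 to compound 3 and a 1.1-fold higher number (0.03 log units; within the scatter) from compound 1 to compound 4, 1.1-fold (0.03 log units) apart, within the scatter of two such steps This is still only two cores, and neither step moves beyond the scatter, so it does not show that a change with a large effect would carry across equally well, nor that this aromatic carbon would tolerate anything other than these two halogens.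

The compounds shown leave open whether the group on this aromatic carbon matters at all: an amine, a carboxylic acid or a longer chain in place of the halogen might shift the number or might leave it where it stands. Also open, as far as these compounds go, is what the substituents on the phenyl groups contribute, as the two cores differ in more than one place and no single change between them can be read from these compounds.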